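Hydroxy on the benzylamino arm: expected effect in compound 4

The source may hold more compounds than are shown below. What is called first, only, known or untested is meant among the compounds shown, and "the series" means these compounds.

Measured compounds:
- compound 1 `N=C(NCc1ccccc1)[C@@H]1CCC(=O)N1Cc1ccccc1` — 20.7%
- compound 2 `N=C(NCc1ccc(O)cc1)[C@@H]1CCC(=O)N1Cc1ccccc1` — 37.6%
- compound 3 `N=C(NCc1ccccc1)[C@@H]1CCC(=O)N1Cc1ccccc1[N+](=O)[O-]` — 25.3%

All three were read in a functional assay on SH-SY5Y cells (Homo sapiens) for cytotoxicity, read by MTT assay, with stated times of 8 h, 30 min and 12 h, tested at 5 uM; on this read-out lower numbers stand for a weaker effect and higher numbers for a stronger effect at the one concentration tested. Compound 3 gives 25.3%, the second highest of the three numbers; the nearest is compound 1, whose value lies below it but within the scatter, and the furthest is compound 2, which lies beyond the scatter above it.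

Compound 4 `N=C(NCc1ccc(O)cc1)[C@@H]1CCC(=O)N1Cc1ccccc1[N+](=O)[O-]` is not yet measured. It differs from compound 3 by hydroxy in place of hydrogen on an aromatic carbon. Going by the values given here, the one measured step that bears on this change is a number 16.9 percentage points higher from compound 1 to compound 2 (beyond the scatter), the same substitution on the same arm of the shared core. Among the compounds with values here, the other step, a number 4.6 percentage points higher from compound 1 to compound 3 (within the scatter), shows only that the nitro group on the other benzyl did little on its own. A rise of similar size to the first step is therefore expected in this assay, a number 14.7 percentage points higher from compound 3 to compound 4 (beyond the scatter). Compound 4 is estimated at 40%, with a range from 28% to 52%.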

Compound 4, a percentage reported as activity, at one concentration (the size of the read-out at that concentration, not a potency): 30.4%
Estimate against measurement, compound 4: 9.6 percentage points above; measured number inside the range.
By their numbers in this assay, from the lowest: compounds 1, 3, 4 and 2 (each within the scatter of the next, the first and the last beyond it).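

With the nitro group on the other benzyl, the change from benzyl to 4-hydroxybenzyl on the benzylamino arm reads in this assay as a number 5.1 percentage points higher from compound 3 to compound 4 (within the scatter), so the hydroxy step no longer stands beyond the scatter on every core shown. The two hydroxy steps still cannot be told apart: the same change on two cores in this assay, a number 16.9 percentage points higher (beyond the scatter) from compound 1 to compound 2 and a number 5.1 percentage points higher (within the scatter) from compound 3 to compound 4, 11.8 percentage points apart, within the scatter of two such steps. The nitro change, now read with the 4-hydroxybenzyl arm in place, gives a number 7.2 percentage points lower from compound 2 to compound 4 (within the scatter), and it stays within the scatter on both cores: the same change on two cores in this assay, a number 4.6 percentage points higher (within the scatter) from compound 1 to compound 3 and a number 7.2 percentage points lower (within the scatter) from compound 2 to compound 4, 11.8 percentage points apart, within the scatter of two such steps.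

Going by these compounds alone, whether the hydroxy step truly depends on the nitro group remains open, since only two pairs bear on it and their gap lies within the scatter. Also open, as far as these compounds go, is whether a methoxy or an amine on the same aromatic carbon would read like hydroxy in this assay.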